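Swapping fluoro for nitro on a benzimidazole-type amylase inhibitor

This account rests on a few compounds, and the source may have more. Where it says the series, first, only, none or still open, it means among the compounds named here.

Three compounds sharing a fused two-ring core were tested in an assay for inhibition of Alpha amylase (Homo sapiens), with a stated time of 10 min; on this read-out lower numbers stand for stronger inhibition and higher numbers for weaker inhibition. Compound 1 `COc1ccc(-c2nc3cc(C)c(C)cc3[nH]2)c(F)c1` gives 2780 nM in this assay. Compound 2 `COc1cc(Br)c(-c2nc3cc(F)ccc3[nH]2)cc1OC` gives 1570 nM, and compound 3 `Oc1c(Cl)cc(Cl)cc1-c1nc2cc(F)ccc2[nH]1` gives 2870 nM. The number for compound 2 sits at the bottom of the three, yet its gaps to compound 1 and to compound 3 both fall within the usual scatter, so the three cannot be told apart with confidence.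

Compound 4 `COc1cc(Br)c(-c2nc3cc([N+](=O)[O-])ccc3[nH]2)cc1OC` has not been measured. It differs from compound 2 by nitro in place of fluoro on an aromatic carbon. Among the compounds with values here, no measured pair shows the effect of this change, so the expected step from compound 2 to compound 4 is a 1.1-fold higher number from compound 2 to compound 4 (0.06 log units; within the scatter), with no direction beyond the scatter anticipated. Compound 4 is therefore estimated at 1800 nM, within a range from 600 nM to 6000 nM.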

Compound 4, half-maximal inhibitory concentration: 1870 nM
Compound 4: the middle estimate sits 1.0-fold (0.02 log units) below what was measured, within the range that was stated.
By their numbers in this assay, from the lowest: compounds 2, 4, 1 and 3 (each within the scatter of the next).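

Nitro in place of fluoro on this aromatic carbon, three heavy atoms for one and two hydrogen-bond acceptors for none, gives a 1.2-fold higher number from compound 2 to compound 4 (0.08 log units; within the scatter) in this assay. At this position on this core, then, these two groups cannot be told apart, despite the difference in their counts. No measurement here speaks to the reason for this result. As far as these compounds go, whether an amine or a carboxylic acid on the same carbon would also stay within the scatter remains open. So does whether the same swap would read alike with different groups on the other ring.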